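This account rests on a few compounds, and the source may have more. Where it says the series, first, only, none or still open, it means among the compounds named here.

Compound 1 `O=c1ccoc2cc(OCc3cn(Cc4ccc(Cl)cc4)nn3)ccc12` and compound 2 `O=c1ccoc2cc(OCc3cn(Cc4cccc(F)c4)nn3)ccc12` share one core and differ only in the halogenated phenyl ring that sits on a saturated chain carbon bound to an aromatic nitrogen. In a functional assay on QGY7701 cells (Homo sapiens) for cytotoxicity, read by MTT assay, with a stated time of 48 h (on this read-out higher numbers stand for weaker inhibition and lower numbers for stronger inhibition), compound 1 gives 41700 nM. For compound 2 this assay gives only a limit, > 100000 nM, which is the limit of > 100000 nM in this assay, at which 1 of the 2 values shown sits. The step of an at least 2.3-fold higher number from compound 1 to compound 2 (0.37 log units; beyond the scatter) changes both the halogen and its place on the ring at once, so it cannot be pinned to one cause. Compound 3 `O=c1ccoc2cc(OCc3cn(Cc4cccc(Cl)c4)nn3)ccc12` keeps the ring placement of compound 2 and differs from it by chloro in place of fluoro on an aromatic carbon. For the measured compounds named here, only that one measured step bears on this change, and it mixes the halogen swap with a move of the halogen, so it offers no clean guide to the halogen alone; chloro does appear in the more potent of the two measured compounds, but there it sits at a different place on the ring. Compound 3 is therefore expected to stay close to the limit, and for compound 3 the expected step is an at least 1.2-fold lower number from compound 2 to compound 3 (0.09 log units; that floor lies within the scatter). The estimate for compound 3 is 80000 nM, between 30000 nM and 200000 nM.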

Compound 3, half-maximal inhibitory concentration: 28400 nM
Beside the measured number, compound 3's estimate is 2.8-fold (0.45 log units) above it; the whole stated range lies above it.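

Holding the ring placement fixed separates the halogen from its place on the ring, which the earlier step could not do: in this assay, chloro in place of fluoro gives an at least 3.5-fold lower number from compound 2 to compound 3 (0.54 log units; beyond the scatter), so at this place the identity of the halogen makes a real difference. The value of compound 2 is a limit of the assay and not a number: the limit of > 100000 nM in this assay, at which 1 of the 3 values shown sits. The place of the chloro can now be read on its own as well, and exchanging 4-chlorophenyl for 3-chlorophenyl gives a 1.5-fold lower number from compound 1 to compound 3 (0.17 log units; within the scatter), so across these two compounds its place on the ring shows no clear effect.

From the compounds shown here alone, it remains open whether bromo would extend the difference seen between fluoro and chloro, or how a group of another kind at this place, such as an amine or a methoxy, would compare with either halogen. Going by these compounds, all three compounds share one core and are read in a single cell line, so whether the chloro and fluoro difference holds on another core or in other cells stays unknown.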